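The source may hold more compounds than are shown below. What is called first, only, known or untested is meant among the compounds shown, and "the series" means these compounds.

Working notes on the aryl hydrazone urea series. The shared core is that of compound 1 `CN(C)CCn1cnnc1-c1cc(Oc2ccc(NC(=O)N/N=C/c3ccc(Cl)cc3)cc2F)ccn1`, which in a functional assay on U-87MG ATCC cells (Homo sapiens) for cytotoxicity, read by MTT assay, with a stated time of 72 h (on this read-out lower numbers stand for stronger inhibition and higher numbers for weaker inhibition), gives 1370 nM. Compound 3 `CN(C)CCn1cnnc1-c1cc(Oc2ccc(NC(=O)N/N=C/c3ccc(O)cc3)cc2F)ccn1` gives 7750 nM in this assay. Compound 2 `CN(C)CCn1cnnc1-c1cc(Oc2ccc(NC(=O)N/N=C/c3ccc(O)c(F)c3)cc2F)ccn1` reaches only the limit of this assay, > 100000 nM. Compound 3 thus holds the highest of the two real numbers; its gap to the nearest one is a 5.7-fold higher number from compound 1 to compound 3 (0.75 log units; beyond the scatter), with hydroxy in place of chloro on an aromatic carbon.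

Compound 4 `CN(C)CCn1cnnc1-c1cc(Oc2ccc(NC(=O)N/N=C/c3cc(Br)c(O)c(Br)c3)cc2F)ccn1` is not yet measured. Its change from compound 3 is 3,5-dibromo-4-hydroxyphenyl in place of 4-hydroxyphenyl on a carbon with a double bond to nitrogen. Going by the values given here, two measured steps bear on it: the hydroxy-for-chloro step above, and an at least 12-fold lower number from compound 2 to compound 3 (1.11 log units; beyond the scatter), hydrogen in place of fluoro on an aromatic carbon, read in reverse as a halogen placed onto the 4-hydroxyphenyl sending the number to the limit (the limit of > 100000 nM in this assay, at which 1 of the 3 values shown sits). Adding two bromines to the same 4-hydroxyphenyl is therefore expected to weaken this assay read-out beyond the scatter, a 2.6-fold higher number from compound 3 to compound 4 (0.41 log units; beyond the scatter), although bromine is not fluorine and compound 1 shows a halogen alone doing well. For compound 4 the estimate is 20000 nM, within 5000 nM to 80000 nM.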

Compound 4, half-maximal inhibitory concentration: > 100000 nM
Compound 4: a limit, no number; the forecaster's own chance of this, stated with the estimate: 25%; at least 5.0-fold (0.69 log units) between middle value and limit.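

Placing two bromines on the 4-hydroxyphenyl, on the carbon with a double bond to nitrogen, gives an at least 12-fold higher number from compound 3 to compound 4 (1.11 log units; beyond the scatter), so the loss seen with fluorine in compound 2 also appears with bromine. Against the 4-chlorophenyl, the same aryl group gives an at least 72-fold higher number from compound 1 to compound 4 (1.86 log units; beyond the scatter); among these compounds, halogen together with the hydroxy goes with the limit, while compound 1, with halogen and no hydroxy, goes against any rule that halogen alone weakens the read-out. The value of compound 4 is a limit, and the step from compound 2 to compound 4 cannot be read: the limit of > 100000 nM in this assay, at which 2 of the 4 values shown sit.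

Going by these compounds, the order of compound 2 and compound 4 therefore remains open. Also open, on these data alone, is how a 3,5-dibromophenyl without the hydroxy, or a methoxy or an amine in place of the hydroxy, would read in this assay.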